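Amine link in place of ether on the shared core

A few compounds are considered here, and "the series" means these few. Any claim that something is new, unique, unknown or untested is made for them only; others in the source may bear on it.

Compound 1, `Nc1cc(N)c2nc(-c3ccccc3)c(Oc3ccc(Cl)c(Cl)c3)nc2c1`: 33900 nM in a functional assay on SR cells (Homo sapiens) for inhibition, read by sulforhodamine B assay, with a stated time of 48 h; on this read-out lower numbers stand for stronger inhibition of growth and higher numbers for weaker inhibition of growth
Compound 2, `CCOC(=O)[C@H](CCC(=O)O)NC(=O)c1ccc(Sc2nc3cc(N)cc(N)c3nc2-c2ccccc2)cc1`: 7760 nM in this assay
Compound 3, `COc1cc(CNc2nc3cc(N)cc(N)c3nc2-c2ccccc2)cc(OC)c1OC`: 891 nM in this assay

Compound 1 carries the highest number of the three; compound 2 lies nearest to it, and compound 3, with the lowest number, lies furthest away. Compound 4, `Nc1cc(N)c2nc(-c3ccccc3)c(NCc3ccc(F)cc3)nc2c1`, differs from compound 1 by (4-fluorobenzyl)amino in place of 3,4-dichlorophenoxy on an aromatic carbon — (4-fluorobenzyl)amino in place of 3,4-dichlorophenoxy on an aromatic carbon. Going by the values given here, no measured pair isolates this single change. Compound 3, which likewise joins a substituted benzyl group to the core through an amine, gives 891 nM, so the step from compound 1 to compound 4 is expected to be a drop well beyond the scatter, a 23-fold lower number from compound 1 to compound 4 (1.35 log units; beyond the scatter). Compound 4 is estimated at 1500 nM, within 400 nM to 6000 nM.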

Compound 4, concentration for 50% growth inhibition: 4070 nM
The estimate for compound 4 lay 2.7-fold (0.43 log units) below the measured number; measured number inside the range.
By their numbers in this assay, from the lowest: compound 3; then compounds 4 and 2 (each within the scatter of the next); then compound 1.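

Going by these compounds alone, this is the first single-place change on the shared core that can be read: at the aromatic carbon next to the ring nitrogen, (4-fluorobenzyl)amino in place of 3,4-dichlorophenoxy gives an 8.3-fold lower number from compound 1 to compound 4 (0.92 log units; beyond the scatter) in this assay. The number at this position thus depends on the group attached there, but the change alters the link and the ring substituents together. No measured evidence bears on the origin of this step.

On these data alone, whether the link or the ring substituents carry the step remains open; (3,4-dichlorobenzyl)amino or 4-fluorophenoxy at this carbon would separate them. As far as these compounds go, how a plain amino group or a longer chain ending in a carboxylic acid would read there is also open.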